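This account rests on a few compounds, and the source may have more. Where it says the series, first, only, none or still open, it means among the compounds named here.

Compound 1 `CCOc1ncc(-c2nc(C(F)(F)F)sc2N2CCN(C(=O)Cn3cnc4ccccc43)[C@H](C)C2)cn1`: in a functional assay on U2OS cells for antagonist activity at C-X-C chemokine receptor type 3 (Homo sapiens), read by beta-arrestin recruitment (a higher number here means a weaker inhibitor, a lower number a stronger inhibitor), compound 1 gives 49 nM.
Compound 2 `CCOc1ncc(-c2nc(C(F)(F)F)sc2N2CCN(C(=O)Cn3ccc4cnccc43)[C@H](C)C2)cn1`: compound 2 gives 23 nM.
Compound 3 `CCOc1ncc(-c2nc(C(F)(F)F)sc2N2CCN(C(=O)Cn3ccc(C(F)(F)F)n3)[C@H](C)C2)cn1`: compound 3 gives 93 nM.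

Compound 3 gives the highest number of the three in this assay. Its gap to compound 1, a 1.9-fold higher number from compound 1 to compound 3 (0.28 log units; within the scatter), lies within the scatter, while its gap to compound 2, a 4.0-fold higher number from compound 2 to compound 3 (0.61 log units; beyond the scatter), lies beyond it. Compound 4 `CCOc1ncc(-c2nc(C(F)(F)F)sc2N2CCN(C(=O)Cn3cnc(C(F)(F)F)n3)[C@H](C)C2)cn1` differs from compound 3 in one place: 3-(trifluoromethyl)-1H-1,2,4-triazol-1-yl in place of 3-(trifluoromethyl)-1H-pyrazol-1-yl on a saturated chain carbon bound to a carbonyl carbon. Within the data shown here, no measured step exchanges one five-membered ring bearing a trifluoromethyl for another; the steps of a 2.1-fold lower number from compound 1 to compound 2 (0.33 log units; beyond the scatter) and a 1.9-fold higher number from compound 1 to compound 3 (0.28 log units; within the scatter) swap whole side groups and bear on this change only loosely. For compound 4 a step of no more than the scatter is expected, a 1.1-fold higher number from compound 3 to compound 4 (0.03 log units; within the scatter). Compound 4 is expected to give 100 nM in this assay, within 40 nM to 250 nM.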

Compound 4, half-maximal inhibitory concentration: 118 nM
For compound 4 the middle estimate is 1.2-fold (0.07 log units) below the measured one; measured number inside the range.
By their numbers in this assay, from the lowest: compound 2; then compounds 1, 3 and 4 (each within the scatter of the next, the first and the last beyond it).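

In this assay, on this saturated chain carbon bound to a carbonyl carbon, 3-(trifluoromethyl)-1H-1,2,4-triazol-1-yl and 3-(trifluoromethyl)-1H-pyrazol-1-yl cannot be told apart, with a 1.3-fold higher number from compound 3 to compound 4 (0.10 log units; within the scatter). Measured against 1H-benzimidazol-1-yl, however, the triazolyl group clears the scatter, with a 2.4-fold higher number from compound 1 to compound 4 (0.38 log units; beyond the scatter), as it does in the step of a 5.1-fold higher number from compound 2 to compound 4 (0.71 log units; beyond the scatter). Nothing measured here gives a reason for these results. The compounds shown leave open what a methyl or a nitrile in place of the trifluoromethyl on the triazole ring would give.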